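A few compounds are considered here, and "the series" means these few. Any claim that something is new, unique, unknown or untested is made for them only; others in the source may bear on it.

Working notes on a small series in a physicochemical assay for lipophilicity, read by HPLC, in phosphate buffer, measured as octanol-water partition, with a stated time of 24 h, at pH 7.4; a lower number here means a more polar compound, a higher number a more lipophilic compound. Compound 1, `Clc1ccc2c(NCCNc3nccc(Cl)n3)ccnc2c1`, and compound 2, `Clc1ccc2c(NCCNc3ccnc(Cl)n3)ccnc2c1`, share a core and differ only in the group on one amine nitrogen: 2-chloropyrimidin-4-yl in place of 4-chloropyrimidin-2-yl on an amine nitrogen. In this assay compound 1 gives 0.501, and compound 2 gives 0.489; the change produced a number 0.01 log units lower from compound 1 to compound 2 (within the scatter), so the two values sit together within the usual scatter. Compound 3, `Clc1ccc2c(NCCCCCCCCNc3nccc(Cl)n3)ccnc2c1`, carries the same 4-chloropyrimidin-2-yl group as compound 1 on a different core; the difference between the two cores is not broken down here. In this assay compound 3 gives 1.51, the highest of the three numbers, beyond the scatter from both compound 1 and compound 2. Compound 4, `Clc1ccc2c(NCCCCCCCCNc3ccnc(Cl)n3)ccnc2c1`, is not yet measured. It stands to compound 3 as compound 2 stands to compound 1: 2-chloropyrimidin-4-yl in place of 4-chloropyrimidin-2-yl on an amine nitrogen. This is the same change at the same place, an amine nitrogen whose other neighbour is a saturated chain carbon. Because the same change gave a number 0.01 log units lower from compound 1 to compound 2 (within the scatter), the step expected now is a number 0.01 log units lower from compound 3 to compound 4 (within the scatter). Compound 4 is therefore estimated at 1.5 in this assay, with an expected range from 1.2 to 1.8.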

Compound 4, distribution coefficient: 1.48
For compound 4 the middle estimate is 0.02 log units above the measured one; the measured number falls inside the stated range.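

In this assay the exchange of 4-chloropyrimidin-2-yl for 2-chloropyrimidin-4-yl on an amine nitrogen gives a number 0.03 log units lower from compound 3 to compound 4 (within the scatter) and, on the core of compound 1, a number 0.01 log units lower from compound 1 to compound 2 (within the scatter) in the earlier pair, so on both cores shown the step stays within the scatter and carries over from one core to the other. This rests on two matched pairs only, which share the same place, an amine nitrogen whose other neighbour is a saturated chain carbon, and it sets no rule for cores or places outside these four compounds. Nothing at hand explains why the exchange gives the same outcome on both cores.

Still open, on these data alone, is whether the same exchange stays within the scatter on a core with a chain longer than that of compound 3, or with an amine or a carboxylic acid on the chain. Also open, as far as these compounds go, is how it reads where the amine nitrogen carries an aromatic ring as its other neighbour rather than a saturated chain carbon.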